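The source may report more compounds than this note shows. Statements on the series, on what has been measured and on what is new or still open speak of the compounds shown alone.

Compound 1 `O=S(=O)(NCCN1CCC(CNC2CCCc3ccccc3C2)CC1)c1cccc2ccccc12` is the parent of this pair. In an assay on isolated protein for inhibition of Neuropeptide Y receptor type 5 (Homo sapiens) (a higher number here means a weaker inhibitor, a lower number a stronger inhibitor), compound 1 gives 210 nM. Within the data shown here, compound 2 `O=S(=O)(NCCN1CCC(CNC2CCCc3ccc(Cl)cc3C2)CC1)c1cccc2ccccc12` carries a chloro in place of hydrogen on an aromatic carbon, and in this assay compound 2 gives 85 nM; the step of a 2.5-fold lower number from compound 1 to compound 2 (0.39 log units; beyond the scatter) is the only measured change available, and it lies beyond the scatter. Among the measured compounds shown here, compound 2 therefore stands with the lower of the two numbers recorded, and compound 1 is its only neighbour.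

Compound 3 `Nc1ccc2c(c1)CC(NCC1CCN(CCNS(=O)(=O)c3cccc4ccccc34)CC1)CCC2` is not yet measured. It differs from compound 2 by the change (amino in place of chloro on an aromatic carbon). For the measured compounds named here, the one measured step, from hydrogen to chloro at the same aromatic carbon, bears on it only indirectly, since no compound with an amino at that position has been measured; the data show that substitution at this carbon can shift the number, but not in which way an amino will do so. The expectation is therefore a modest step, most likely upward, as a 2.1-fold higher number from compound 2 to compound 3 (0.33 log units; beyond the scatter), with compound 3 expected at 180 nM and a range from 60 nM to 550 nM.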

Compound 3, half-maximal inhibitory concentration: 52 nM
The estimate for compound 3 lay 3.5-fold (0.54 log units) above the measured number, and the stated range ends above it.
By their numbers in this assay, from the lowest: compounds 3 and 2 (each within the scatter of the next); then compound 1.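

In this assay, replacing chloro with amino at this aromatic carbon gives a 1.6-fold lower number from compound 2 to compound 3 (0.21 log units; within the scatter) and so does not separate the two groups, even though amino counts 1 hydrogen-bond donor and 1 hydrogen-bond acceptor and chloro counts none. Measured against the parent, amino in place of hydrogen gives a 4.0-fold lower number from compound 1 to compound 3 (0.61 log units; beyond the scatter) and thus provides a second group, after chloro, whose number at this carbon lies beyond the scatter from that of compound 1 and on the same side. The result therefore shows that the lower number at this position is not confined to chloro, but no measurement available here explains how either group produces it.

The compounds shown leave open whether a methoxy group, a hydroxyl group or an acetylated amine at this carbon would give a number close to those of compound 2 and compound 3, or whether a larger group such as a phenyl ring would be accommodated as well. They also leave open whether chloro and amino would give similar numbers on another aromatic carbon of the same ring.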